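The compounds below may be only part of what the source reports. "The series", "measured", "known", "first", "only" and "open" are said of these compounds alone.

Of the compounds shown here, three built on a shared core have been tested in a functional assay on cells for antagonist activity at C-X-C chemokine receptor type 4 (Homo sapiens), read by fluorescence and calcium flux, with stated times of 25 min and 90 s; on this read-out higher numbers stand for weaker inhibition and lower numbers for stronger inhibition. Compound 1 `c1ccc2c(c1)CN[C@@H](CN(CCCCNC1CCOCC1)[C@H]1CCCc3cccnc31)C2` gives 29.4 nM. Compound 2 `CC1(C)CCC(NCCCCN(C[C@H]2Cc3ccccc3CN2)[C@H]2CCCc3cccnc32)CC1` gives 77.6 nM, and compound 3 `C(=C/CN(C[C@H]1Cc2ccccc2CN1)[C@H]1CCCc2cccnc21)\CNC1CCOCC1` gives 15.5 nM. The core of compound 1 and the core of compound 3 differ in one respect, (3-((oxan-4-yl)amino)prop-1-en-1-yl in place of 3-((oxan-4-yl)amino)propyl on a saturated chain carbon bound to an amine nitrogen), and this difference amounted to a 1.9-fold lower number from compound 1 to compound 3 (0.28 log units; within the scatter), so the two values are not distinguishable here.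

One structural change appears twice among these compounds. Between the two measured ones it reads (4,4-dimethylcyclohexyl in place of oxan-4-yl on an amine nitrogen), and it produced a 2.6-fold higher number from compound 1 to compound 2 (0.42 log units; beyond the scatter). Compound 4 `CC1(C)CCC(NC/C=C/CN(C[C@H]2Cc3ccccc3CN2)[C@H]2CCCc3cccnc32)CC1` has not yet been measured; it carries the same change relative to compound 3, (4,4-dimethylcyclohexyl in place of oxan-4-yl on an amine nitrogen), at a place described in identical words, so the change is the same one.

Going by the values given here, because the only precedent is a 2.6-fold higher number from compound 1 to compound 2 (0.42 log units; beyond the scatter), a comparable step is expected in this assay, namely a 2.6-fold higher number from compound 3 to compound 4 (0.41 log units; beyond the scatter), with the usual uncertainty of a single instance. Compound 4 is therefore expected to give about 40 nM, most likely between 20 nM and 85 nM.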

Compound 4, half-maximal inhibitory concentration in the C-X-C chemokine receptor type 4 assay: 64.6 nM
For compound 4 the middle estimate is 1.6-fold (0.21 log units) below the measured one; low and high end bracket the measured number.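

In the C-X-C chemokine receptor type 4 assay, putting 4,4-dimethylcyclohexyl in place of oxan-4-yl on an amine nitrogen gave a 4.2-fold higher number from compound 3 to compound 4 (0.62 log units; beyond the scatter), and the step set beside its earlier counterpart reads: the same change on two cores in the C-X-C chemokine receptor type 4 assay, a 2.6-fold higher number (0.42 log units; beyond the scatter) from compound 1 to compound 2 and a 4.2-fold higher number (0.62 log units; beyond the scatter) from compound 3 to compound 4, 1.6-fold (0.20 log units) apart, within the scatter of two such steps The change therefore carried over from one core to the other in direction, and the two steps cannot be told apart in size. Going by these compounds alone, this rests on only two pairs of compounds, however, and it does not show that the step would hold on other cores, nor which part of the exchanged group accounts for it.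

The compounds shown leave open whether the oxygen of the oxan-4-yl ring or the two methyl groups matter, a question that a plain cyclohexyl or a piperidin-4-yl group on the same amine nitrogen would address. In a physicochemical assay for permeability, using PAMPA, with a stated time of 4 h, at pH 5.5, tested at 100 uM (a lower number here means that the compound crosses the layer more slowly, a higher number that the compound crosses the layer faster), compound 3 gives 105 nm/s, and compound 4 gives "not determined" (no result reported), so the step between them cannot be read.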